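Sulfonyl series: the step to compound 4

The source may hold more compounds than are shown below. What is called first, only, known or untested is meant among the compounds shown, and "the series" means these compounds.

In a functional assay on DU-145 cells (Homo sapiens) for inhibition, read by trypan blue exclusion, with a stated time of 72 h (a lower number here means a stronger inhibitor, a higher number a weaker inhibitor), compound 1 (`COc1ccc(S(=O)(=O)c2cc3cnc(Nc4ccc5[nH]ccc5c4)nc3n(C)c2=O)cc1`) gives 500 nM and compound 2 (`Cn1c(=O)c(S(=O)(=O)c2ccc(F)cc2)cc2cnc(Nc3ccc4[nH]ccc4c3)nc21`) gives 300 nM while compound 3 (`Cn1c(=O)c(S(=O)(=O)c2ccc(O)cc2)cc2cnc(Nc3ccc4[nH]ccc4c3)nc21`) gives 250 nM and so stands within the scatter of both. Compound 4 (`Cn1c(=O)c(S(=O)(=O)Nc2ccc(F)cc2)cc2cnc(Nc3ccc4[nH]ccc4c3)nc21`) has (4-fluorophenyl)amino in place of 4-hydroxyphenyl on a sulfonyl sulfur. The measured steps are a 1.7-fold lower number from compound 1 to compound 2 (0.22 log units; within the scatter) and a 2.0-fold lower number from compound 1 to compound 3 (0.30 log units; within the scatter) and a 1.2-fold lower number from compound 2 to compound 3 (0.08 log units; within the scatter) and all stay within the scatter. They only exchange a group on an aromatic carbon, and none alters what the sulfonyl sulfur carries, so they guide this change only weakly. In this assay a small step toward a higher number, within the scatter, is expected (a 1.6-fold higher number from compound 3 to compound 4 (0.20 log units; within the scatter)). Compound 4 is estimated at 400 nM with an expected range of 130 nM to 1200 nM for its value.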

Compound 4, half-maximal inhibitory concentration: 5000 nM
Beside the measured number, compound 4's estimate is 13-fold (1.10 log units) below it, outside the stated range (above it).
By their numbers in this assay, from the lowest: compounds 3, 2 and 1 (each within the scatter of the next); then compound 4.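

In this assay, what the sulfonyl sulfur carries counts for far more than the group on the aromatic carbon. With the 4-fluorophenyl ring kept, adding the amino link alone costs heavily (a 17-fold higher number from compound 2 to compound 4 (1.22 log units; beyond the scatter)), and the steps from the other two sulfones are also beyond the scatter (a 20-fold higher number from compound 3 to compound 4 (1.30 log units; beyond the scatter); a 10-fold higher number from compound 1 to compound 4 (1.00 log units; beyond the scatter)). Nothing available explains this loss.

Open, going by these compounds, is whether the loss is specific to the amino link, or also follows with a methylene link or a methylated amino link. Also open, on these data alone, is whether hydroxy or methoxy on the (phenyl)amino ring changes it.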